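Replacing the carbamoylamino arm: estimate for compound 4

The source may report more compounds than this note shows. Statements on the series, on what has been measured and on what is new or still open speak of the compounds shown alone.

Compound 1 `COc1cc(NC(C)CCCNC(=O)NNC(=O)Nc2cccc(F)c2)c2ncccc2c1` is measured in a functional assay on NCI-H460 cells (Homo sapiens) for inhibition, read by MTT assay, with a stated time of 72 h (a higher number here means a weaker inhibitor, a lower number a stronger inhibitor), where compound 1 gives 50000 nM. Compound 1 stands second highest of the three numbers shown: compound 2 `COc1cc(NC(C)CCCNC(=O)NNC(=O)Nc2ccc(Cl)cc2)c2ncccc2c1` gives 63000 nM, and compound 3 `COc1cc(NC(C)CCCNC(=O)Nc2ccc(Br)cc2)c2ncccc2c1` gives 30000 nM. Compound 4 `COc1cc(NC(C)CCCNC(=O)Nc2ccc(Cl)cc2)c2ncccc2c1` is not yet measured. It differs from compound 1 as follows: 4-chlorophenyl in place of ((3-fluorophenyl)carbamoyl)amino on an amide-type nitrogen.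

Among the compounds with values here, two measured steps bear on this change. The step of a 1.7-fold lower number from compound 1 to compound 3 (0.22 log units; within the scatter) makes the same kind of replacement with 4-bromophenyl entering, and the step of a 2.1-fold lower number from compound 2 to compound 3 (0.32 log units; beyond the scatter) is the parallel replacement starting from the 4-chlorophenyl analogue. The step of a 1.3-fold higher number from compound 1 to compound 2 (0.10 log units; within the scatter) shows that swapping the aryl group on the carbamoyl arm alone changes little. Compound 4 carries 4-chlorophenyl where compound 3 carries 4-bromophenyl, so the number for compound 4 is expected to land close to that of compound 3. Compound 4 is therefore expected to show a step of a 1.6-fold lower number from compound 1 to compound 4 (0.19 log units; within the scatter), small and downward, at most just beyond the scatter. For compound 4 the estimate in this assay is 32000 nM, with a range from 15000 nM to 70000 nM.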

Compound 4, half-maximal inhibitory concentration: 34000 nM
The estimate for compound 4 lay 1.1-fold (0.03 log units) below the measured number; low and high end bracket the measured number.
By their numbers in this assay, from the lowest: compounds 3, 4, 1 and 2 (each within the scatter of the next, the first and the last beyond it).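

In this assay, chloro in place of bromo on an aromatic carbon gives a 1.1-fold higher number from compound 3 to compound 4 (0.05 log units; within the scatter) and so does not separate the two halogens in this series. With the aryl halogen held constant, 4-chlorophenyl in place of ((4-chlorophenyl)carbamoyl)amino gives a 1.9-fold lower number from compound 2 to compound 4 (0.27 log units; within the scatter), and the change from the 3-fluorophenyl arm gives a 1.5-fold lower number from compound 1 to compound 4 (0.17 log units; within the scatter), so the step of a 2.1-fold lower number from compound 2 to compound 3 (0.32 log units; beyond the scatter) does not establish a general effect of losing the carbamoylamino arm. Nothing available bears on why these numbers stay so close.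

Still open, from the compounds shown here alone, is whether any group on this amide-type nitrogen can move the number well away from this narrow band. The compounds shown hold no carboxylic acid or amine in place of the halogen, and no longer alkyl chain in place of 4-chlorophenyl.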